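Swapping the aryl group on the piperazine of compound 2

The compounds below may be only part of what the source reports. "The series", "measured", "known", "first", "only" and "open" are said of these compounds alone.

Compounds measured so far:
compound 1 `COCC(C(=O)N1CCN(c2cccc(C(F)(F)F)c2)CC1)N1C(=O)CCC1=O` – 100%
compound 2 `CC(C(=O)N1CCN(c2ccc(Cl)cc2)CC1)N1C(=O)CCC1=O` – 0%
compound 3 `CCC(C(=O)N1CCN(c2ccc(F)cc2)CC1)N1C(=O)CCC1=O` – 25%

Of the compounds shown here, three sharing one core have been tested in a functional assay on the whole organism (strain Swiss) with Mus musculus as the target, in the maximal electroshock model, with a stated time of 1 h, at a dose of 300 mg/kg by the intraperitoneal route; a lower number here means a weaker effect, a higher number a stronger effect of the compound at the dose given. Compound 1 `COCC(C(=O)N1CCN(c2cccc(C(F)(F)F)c2)CC1)N1C(=O)CCC1=O` gives 100% in this assay. Compound 2 `CC(C(=O)N1CCN(c2ccc(Cl)cc2)CC1)N1C(=O)CCC1=O` gives 0%, the lowest of the three numbers. Its nearest neighbour is compound 3 `CCC(C(=O)N1CCN(c2ccc(F)cc2)CC1)N1C(=O)CCC1=O`, which gives 25%, a value higher than that of compound 2 by a margin beyond the usual scatter; compound 1 stands higher still, far beyond the scatter. No pair of these compounds differs in one place only, so no single change can yet be tied to a single shift in the read-out.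

Compound 4 `Cc1cccc(N2CCN(C(=O)C(C)N3C(=O)CCC3=O)CC2)c1` has not been measured. It differs from compound 2 in one place: 3-methylphenyl in place of 4-chlorophenyl on an amine nitrogen in a ring

Since nothing measured isolates this change, any expectation rests on the spread between the three known values. The step from compound 2 to compound 4 is expected to be a modest rise, a number 20 percentage points higher from compound 2 to compound 4 (beyond the scatter), small enough that it may fall within the scatter. In this assay compound 4 is therefore estimated to give 20%, with a range from 0% to 55%.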

Compound 4, a percentage reported as activity, at one dose (the size of the read-out at that dose, not a potency): 0%
Estimate against measurement, compound 4: 20 percentage points above; measured number inside the range.
By their numbers in this assay, from the lowest: compounds 2 and 4 (each within the scatter of the next); then compound 3; then compound 1.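

Among these compounds, this is the first pair of compounds that differ in one place only, so one change can now be tied to its outcome: in this assay, putting 3-methylphenyl in place of 4-chlorophenyl on the amine nitrogen in the ring gives no change at the digits printed from compound 2 to compound 4 (within the scatter). With the rest of the molecule held constant, this swap of one substituted phenyl group for another does not bring out any measurable effect at the dose given, since compound 2 gives 0% and compound 4 gives 0%. Nothing available explains this outcome.

Because the pair sits at the bottom of the scale, it cannot show whether one of these two groups is worse than the other, and it says little about this position in general, only about these two groups on this particular core. On these data alone, it also remains open whether a methoxy or a nitrile on the phenyl ring would give a read-out different from that of compound 2, or whether the same aryl swap would matter with a longer chain in place of the methyl group on the carbon that carries the amide carbonyl.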